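The source may hold more compounds than are shown below. What is called first, only, known or untested is meant among the compounds shown, and "the series" means these compounds.

Measured so far:
- compound 1 `CCCCc1cnc(C(CCCO)Cc2ccc(-c3ccccc3C(=O)O)cc2)[nH]1` gives 1900 nM
- compound 2 `COc1ccccc1Cc1cnc(CCc2ccc(-c3ccccc3C(=O)O)cc2)[nH]1` gives 1720 nM

Both values come from an in vitro functional assay on cells for agonist activity at Bombesin receptor subtype-3 (Homo sapiens), read by luminescence and calcium flux; on this read-out higher numbers stand for an effect only at larger amounts of compound and lower numbers for an effect already at smaller amounts. Among the compounds with values here, compound 1 and compound 2 differ from each other in several places at once, so no single step between them can be named; all that their two numbers show is that they sit within the scatter of each other. Within the data shown here, compound 2 therefore stands on the same level as compound 1, the only other measured compound, with no meaningful gap between them.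

Compound 3 `O=C(O)c1ccccc1-c1ccc(CCc2ncc(Cc3ccccc3)[nH]2)cc1` has not yet been measured in this assay. It is made from compound 2 by one change: hydrogen in place of methoxy on an aromatic carbon. Seen one bond further out, the 2-methoxybenzyl of compound 2 becomes a plain benzyl in compound 3, with everything else kept.

Among the measured compounds shown here, no measured pair shows what this change does here, so the expectation rests only on the narrow band the two known values occupy. The step of a 1.5-fold higher number from compound 2 to compound 3 (0.16 log units; within the scatter) is expected to be small, at most a modest weakening, and may stay within the scatter. Compound 3 is therefore estimated at 2500 nM, within a range from 900 nM to 8000 nM.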

Compound 3, half-maximal effective concentration: 205 nM
Beside the measured number, compound 3's estimate is 12-fold (1.09 log units) above it; measured number outside the range, below it.
By their numbers in this assay, from the lowest: compound 3; then compounds 2 and 1 (each within the scatter of the next).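

Taking the methoxy off this aromatic carbon is the only change in the series so far that can be read at a single place, and in this assay it gives an 8.4-fold lower number from compound 2 to compound 3 (0.92 log units; beyond the scatter). This step lies beyond the usual scatter, so what this carbon of the benzyl ring carries clearly matters, which compounds 1 and 2 could not show: they differ in several places at once, and their numbers sit within the scatter of each other. Nothing measured here explains why the plain benzyl gives the lower number, and the size of the step alone supplies no cause.

One step cannot tell whether this result is particular to methoxy or whether other groups on the same aromatic carbon, such as a fluorine, a chlorine or a hydroxyl, would also give a higher number than hydrogen. As far as these compounds go, it also remains open whether the benzyl itself could give way to a longer chain such as phenethyl, or to a pyridylmethyl group, and still keep a number as low as that of compound 3 at 205 nM.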